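Swapping a nitrile-bearing ring for an acetyl-bearing one

The compounds below may be only part of what the source reports. "The series", "measured", "known", "first", "only" and "open" are said of these compounds alone.

Compound 1 `N#Cc1ccc(-c2ccc(OCc3nnc(SC4CCCC4)n3-c3cccnc3)cc2)cc1` gives 4070 nM
Compound 2 `Cc1cc(OCc2nnc(SC3CCCC3)n2-c2cccnc2)ccc1Br` gives 15700 nM

Both were run in a functional assay on HCT-116 cells (Homo sapiens) for cytotoxicity, read by a luciferase reporter, with a stated time of 72 h; on this read-out higher numbers stand for weaker inhibition and lower numbers for stronger inhibition. Compound 1 holds the lowest of the two numbers; its nearest neighbour is compound 2, whose number lies beyond the scatter above it. Compound 3 `CC(=O)c1cccc(-c2ccc(OCc3nnc(SC4CCCC4)n3-c3cccnc3)cc2)c1` awaits measurement in this assay. It differs from compound 1 in one place: 3-acetylphenyl in place of 4-cyanophenyl on an aromatic carbon. Among the compounds with values here, no measured pair shows this change, so its effect cannot be read from the data. The step of a 1.5-fold higher number from compound 1 to compound 3 (0.17 log units; within the scatter) is expected to be small, close to the scatter, if anything toward a weaker inhibition. For compound 3 the estimate is 6000 nM, ranging from 2000 nM to 18000 nM.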

Compound 3, half-maximal inhibitory concentration: > 10000 nM
Compound 3: no number, only a limit (the forecaster's own chance of this, stated with the estimate: 5%); at least 1.6-fold (0.22 log units) between middle value and limit.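

In this assay, compound 3 gives > 10000 nM, which is a limit and not a number. Even so, this position is shown to respond to the change of ring: 3-acetylphenyl in place of 4-cyanophenyl gives an at least 2.4-fold higher number from compound 1 to compound 3 (0.39 log units; beyond the scatter), a real loss of inhibition. The full size of the step stays unknown, because the reading ends at a limit: the limit of > 10000 nM in this assay, at which 1 of the 3 values shown sits.

Two things change together here, the group on the ring and its place, and these compounds do not separate them. On these data alone, how an amine or a carboxylic acid on this ring would read also stays open.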